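Aromatic substituent swap on compound 3: inhibition outlook

The source may report more compounds than this note shows. Statements on the series, on what has been measured and on what is new or still open speak of the compounds shown alone.

Compound 1 `Nc1cccc(CNc2cc(Br)cc3[nH]ncc23)c1`, compound 2 `ONc1ccc(CNc2cc(Br)cc3[nH]ncc23)cc1` and compound 3 `Nc1cc(CNc2cc(Br)cc3[nH]ncc23)ccc1O` share one core. In an assay for inhibition of Tryptophan 2,3-dioxygenase (Homo sapiens), with a stated time of 1 h, tested at 10 uM (on this read-out lower numbers stand for less inhibition and higher numbers for more inhibition at the one concentration tested (going by the name of the read-out)), compound 1 gives "not active" (no number reported). In this assay compound 2 gives 6%. In this assay compound 3 gives "not active" (no number reported), so no single number places it; it stands beside compound 1 as a further entry without a number, while compound 2 carries the only number shown. Compound 4 `Cc1cc(CNc2cc(Br)cc3[nH]ncc23)ccc1O` differs from compound 3 by methyl in place of amino on an aromatic carbon. Among the compounds with values here, no step between measured compounds is known, so this change is untested; with compound 2 at 6% and compound 3 without a number, any step is expected to stay within the scatter, in no clear direction. Compound 4 is estimated at 5% in this assay, in the range 0% to 15%.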

Compound 4, a percentage reported as inhibition, at one concentration (the size of the read-out at that concentration, not a potency): 30%
For compound 4 the middle estimate is 25 percentage points below the measured one; measured number above the stated range.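

No new step can be read: in this assay compound 3 gives "not active" (no number reported) without a number, so it cannot be set against compound 4 at 30% here. The compounds shown leave open how methyl and amino compare at this place on the shared core. No data shown account for the result.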